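A few compounds are considered here, and "the series" means these few. Any claim that something is new, unique, unknown or untested is made for them only; others in the source may bear on it.

Measured so far in a physicochemical assay for lipophilicity; a lower number here means a more polar compound, a higher number a more lipophilic compound:
compound 1, `CC(C)CC(NC(=O)C(CC(=O)O)NC(=O)CCCOc1ccc(C(=N)N)cc1)C(=O)O`, gives 1.47;
compound 2, `CC(C)(C)CC(NC(=O)C(CC(=O)O)NC(=O)CCCOc1ccc(C(=N)N)cc1)C(=O)O`, gives 1.59;
compound 3, `CC(C)[C@H](NC(=O)[C@H](CC(=O)O)NC(=O)CCCOc1ccc(C(=N)N)cc1)C(=O)NC1CCCCC1`, gives 1.38.

Compound 3 has the lowest of the three numbers in this assay, but its gaps to compound 1 and to compound 2 both lie within the scatter, so the three stand together. Among the compounds with values here, the one step between measured compounds, a number 0.12 log units higher from compound 1 to compound 2 (within the scatter), is a small change on a saturated chain and stays within the scatter.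

Compound 4, `CC(C)[C@H](NC(=O)[C@H](CC(=O)O)NC(=O)CCCOc1ccc(C(=N)N)cc1)C(=O)N1CCS(=O)(=O)CC1`, is not yet measured. It differs from compound 3 in one place: 1,1-dioxothiomorpholin-4-yl in place of cyclohexylamino on a carbonyl carbon. Within the data shown here, no measured step touches this kind of change; the step from compound 1 to compound 2 concerns only a methyl on a chain and does not bear on an exchange of one ring for another at the carbonyl carbon. The expectation for compound 4 therefore rests on the structural change alone, and a step downward beyond the scatter is expected, a number 1.18 log units lower from compound 3 to compound 4 (beyond the scatter). Compound 4 is estimated at 0.2 in this assay, with a range from -0.6 to 1.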

Compound 4, partition coefficient: 0.804
Compound 4: middle estimate off by 0.60 log units, on the low side; the range from low to high includes it.
By their numbers in this assay, from the lowest: compound 4; then compounds 3, 1 and 2 (each within the scatter of the next).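

At the carbonyl carbon, 1,1-dioxothiomorpholin-4-yl in place of cyclohexylamino moves the number in this assay beyond the scatter (a number 0.58 log units lower from compound 3 to compound 4 (beyond the scatter)), which shows that this position responds to an exchange of one ring group for another. Within the data shown here, the only earlier step, a methyl on a saturated chain, stayed within the scatter and said nothing about this place. The exchange goes from 1 hydrogen-bond donor and 0 acceptors to 0 donors and 2 acceptors, but nothing available explains the step.

The compounds shown leave open how much of the step belongs to the ring and how much to the lost donor; a piperidin-1-yl or morpholin-4-yl group on the same carbonyl carbon would separate the two. Also open, from the compounds shown here alone, is whether the same exchange gives a similar step with a different chain on the shared core.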